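The source may report more compounds than this note shows. Statements on the series, on what has been measured and on what is new or still open speak of the compounds shown alone.

Two ureas built on a shared core have been tested in a functional assay on the whole organism (strain albino) with Mus musculus as the target, at a dose of 100 mg/kg by the intraperitoneal route; on this read-out higher numbers stand for more inhibition at the one dose given (going by the name of the read-out) and lower numbers for less inhibition. Compound 1 `Cc1ccc(NC(=O)Nn2c(-c3ccccc3)nc3ccccc3c2=O)cc1` carries a phenyl group on the core and a methyl on the aniline ring; in this assay compound 1 gives 54%. Compound 2 `CCOc1ccc(NC(=O)Nn2c(CC)nc3ccccc3c2=O)cc1` carries an ethyl group on the core and an ethoxy on the aniline ring; in this assay compound 2 gives 50%. Compound 2 stands lowest of the two numbers, but its nearest neighbour, compound 1, lies within the scatter of it, so the two values show no real separation.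

Compound 3 `CCOc1ccc(NC(=O)Nn2c(-c3ccccc3)nc3ccccc3c2=O)cc1` has not been measured. Its difference from compound 2 is phenyl in place of ethyl on an aromatic carbon. For the measured compounds named here, no step between measured compounds covers this change directly. Since compound 1 with 54% and compound 2 with 50% sit within the scatter of each other, the expected step of a number 3 percentage points higher from compound 2 to compound 3 (within the scatter) is small and in no clear direction. Compound 3 is therefore estimated at 53%, within 40% to 66%.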

Compound 3, a percentage reported as inhibition, in the whole organism at one dose (the size of the read-out at that dose, not a potency): 53%
Compound 3: the middle estimate sits on the measured number at the digits printed, and the stated range covers the measured number.
By their numbers in this assay, from the lowest: compounds 2, 3 and 1 (each within the scatter of the next).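

In this assay, phenyl in place of ethyl on the aromatic carbon between two ring nitrogen atoms comes to a number 3 percentage points higher from compound 2 to compound 3 (within the scatter), so this position takes a six-membered aromatic ring as well as a two-carbon chain with no separation in the read-out. For the compounds shown here, compound 3 also supplies the first one-place comparison on the aniline ring, where ethoxy in place of methyl comes to a number 1 percentage points lower from compound 1 to compound 3 (within the scatter), and this change likewise shows no separation. No independent data are available to explain either step.

The compounds shown leave open whether an amine or a carboxylic acid at the position of the ethyl and phenyl groups would move the read-out beyond the scatter. From the compounds shown here alone, it is also open whether a longer chain or a chlorine on the aniline ring would do so.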